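Carbamoyl in Place of Diethylamino: Expecting Compound 3

A few compounds are considered here, and "the series" means these few. Any claim that something is new, unique, unknown or untested is made for them only; others in the source may bear on it.

Compound 1 `Cc1ccc(C(=O)N2N=C(c3cc4ccccc4oc3=O)CC2c2ccccc2)cc1` gives 52300 nM in a functional assay on HepG2 cells (Homo sapiens) for cytotoxicity, read by MTT assay, with a stated time of 48 h; a higher number here means a weaker inhibitor, a lower number a stronger inhibitor.
Compound 2 `CCN(CC)C1CCN(CC(=O)N2N=C(c3cc4ccccc4oc3=O)CC2c2ccccc2)CC1` gives 19300 nM in this assay.

For the measured compounds named here, compound 2 holds the lower of the two numbers; its only neighbour is compound 1, and the step of a 2.7-fold lower number from compound 1 to compound 2 (0.43 log units; beyond the scatter) came with (4-(diethylamino)piperidin-1-yl)methyl in place of 4-methylphenyl on a carbonyl carbon. Compound 3 `NC(=O)C1CCN(CC(=O)N2N=C(c3cc4ccccc4oc3=O)CC2c2ccccc2)CC1` differs from compound 2 by carbamoyl in place of diethylamino on a saturated ring carbon. Going by the values given here, no measured step bears on this change, as the one step known concerns a different part of the shared core. The expected step is therefore a 1.3-fold higher number from compound 2 to compound 3 (0.11 log units; within the scatter), not beyond the scatter. Compound 3 is estimated at 25000 nM, ranging from 8000 nM to 75000 nM.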

Compound 3, half-maximal inhibitory concentration: 19300 nM
Compound 3: middle estimate off by 1.3-fold (0.11 log units), on the high side; measured number inside the range.
By their numbers in this assay, from the lowest: compounds 2 and 3 (each within the scatter of the next); then compound 1.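

In this assay, carbamoyl in place of diethylamino on a saturated ring carbon gives no change at the digits printed from compound 2 to compound 3 (within the scatter), so this ring carbon accepts two groups with different heavy-atom and hydrogen-bond donor counts without a readable shift. The lower number relative to compound 1 therefore does not require diethylamino: a 2.7-fold lower number from compound 1 to compound 3 (0.43 log units; beyond the scatter). No measurement here explains why the two groups read alike. On these data alone, whether a carboxylic acid or a primary amine on this ring carbon would also leave the number in place remains open, as does the effect of an open chain in place of 4-carbamoylpiperidin-1-yl.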